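The source may hold more compounds than are shown below. What is called first, only, known or untested is meant among the compounds shown, and "the series" means these compounds.

Measured compounds:
- Compound 1, `CN(c1ccc2cc(NC(=O)CCc3ccc(C(F)(F)F)cc3)ccc2n1)C1CCCC1`: 2 nM
- Compound 3, `O=C(CCc1ccc(C(F)(F)F)cc1)Nc1ccc2nc(N3CC4CCC3CC4)ccc2c1`: 3 nM
- Compound 2, `O=C(CCCCCCCCCCCCc1ccc(C(F)(F)F)cc1)Nc1ccc2nc([N+]34CCC(CC3)CC4)ccc2c1`: 5 nM

All three were tested in an assay on isolated protein for displacement of a labelled ligand from melanin-concentrating hormone receptor 1 (Homo sapiens) (a higher number here means a weaker inhibitor, a lower number a stronger inhibitor), and share a core that carries an amine on one aromatic carbon and an amide-linked chain ending in a trifluoromethylphenyl group on the other side. Compound 1 gives 2 nM, the lowest of the three numbers; compound 3 sits within the usual scatter of it. Compound 2, which differs from compound 1 in more than one place, lies beyond the scatter of compound 1. In this assay compound 2 gives 5 nM.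

Compound 4, `CC1CCCN1c1ccc2cc(NC(=O)CCc3ccc(C(F)(F)F)cc3)ccc2n1`, has not yet been measured. It differs from compound 1 in one place: 2-methylpyrrolidin-1-yl in place of cyclopentyl(methyl)amino on an aromatic carbon. Within the data shown here, the only single-point step measured at this aromatic carbon is a 1.5-fold higher number from compound 1 to compound 3 (0.18 log units; within the scatter), where one amine was exchanged for another without a change beyond the scatter. Among the measured compounds shown here, that step suggests the amine at this position can be varied without a large effect, although it covers only one exchange and gives no direct evidence for a smaller ring like 2-methylpyrrolidin-1-yl.

On that basis compound 4 is expected to stay close to compound 1, with a step of a 2.0-fold higher number from compound 1 to compound 4 (0.30 log units; within the scatter) that may fall within the scatter. The estimate for compound 4 in this assay is 4 nM, with a likely range from 1.5 nM to 12 nM.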

Compound 4, half-maximal inhibitory concentration: 5 nM
Compound 4: the middle estimate sits 1.3-fold (0.10 log units) below what was measured; measured number inside the range.
By their numbers in this assay, from the lowest: compounds 1, 3, 2 and 4 (each within the scatter of the next, the first and the last beyond it).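

In this assay, among these compounds, 2-methylpyrrolidin-1-yl in place of cyclopentyl(methyl)amino gives a 2.5-fold higher number from compound 1 to compound 4 (0.40 log units; beyond the scatter), the first single exchange at this aromatic carbon that goes beyond the scatter, though only modestly. Among the compounds shown here, measured against the amine of compound 3, the same group gives a 1.7-fold higher number from compound 3 to compound 4 (0.22 log units; within the scatter), so the two exchanges that lead to compound 4 read differently: only the one from compound 1 is larger than repeated measurements would normally produce. The choice of amine here can therefore shift the number, but across these three amines the shift stays small, and nothing measured here explains it.

On these data alone, how pyrrolidin-1-yl without its methyl, a six-membered piperidin-1-yl ring or an open-chain dimethylamino group would compare on this carbon remains open, so the separate contributions of the methyl and of the ring cannot yet be told apart. Also open, as far as these compounds go, is whether the same small shift between amines would hold if the amide side carried a longer chain instead of the short one shared by compounds 1, 3 and 4.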